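Shortening a Chain on a Glutamate Receptor Modulator

The source may report more compounds than this note shows. Statements on the series, on what has been measured and on what is new or still open speak of the compounds shown alone.

Of the compounds shown here, three sharing one core have been measured in an assay on HEK293 cells for positive allosteric modulation of metabotropic glutamate receptor 3 (Rattus norvegicus), read by thallium flux, with a stated time of 2.5 min; on this read-out higher numbers stand for larger maximal responses and lower numbers for smaller maximal responses. Compound 1 `Cc1c(OCCCCOc2ccc(C(=O)O)cc2)ccc(C(=O)CC(C)C)c1O` gives 51.9% in this assay. Compound 2 `CCCC(=O)c1ccc(OCCCCOc2ccc(C(=O)O)cc2C)c(C)c1O` gives 40.5%, and compound 3 `Cc1c(OCCCCOc2ccc(C(=O)O)cc2F)ccc(C(=O)CC2CCCC2)c1O` gives 31.2%. Among these three numbers compound 2 stands in the middle: compound 1 lies higher than compound 2 by an amount beyond the usual scatter, while the gap between compound 2 and compound 3 is within that scatter, so those two cannot be told apart on this read-out.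

The next compound, compound 4 `CCC(=O)c1ccc(OCCCCOc2ccc(C(=O)O)cc2C)c(C)c1O`, is not yet measured. It is built from compound 2 by one change: hydrogen in place of methyl on a saturated chain carbon, two bonds along the chain from a carbonyl carbon. Put differently, the propylcarbonyl of compound 2 becomes a propanoyl in compound 4, with nothing else altered.

Within the data shown here, no measured pair among the three compounds shows the effect of this particular change on its own, so there is no direct guide. Since the change removes only one carbon from a chain, the expectation is a modest shift at most, likely not beyond the scatter, in either direction. The expected step from compound 2 to compound 4 is a number 2.5 percentage points lower from compound 2 to compound 4 (within the scatter). Compound 4 is therefore estimated at 38% in this assay, within a range from 25% to 52%.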

Compound 4, largest response reached (reported as percent of maximum), in percent of the reference or control that the assay uses: 22.7%
The estimate for compound 4 lay 15.3 percentage points above the measured number, and the stated range ends above it.
By their numbers in this assay, from the lowest: compounds 4, 3 and 2 (each within the scatter of the next, the first and the last beyond it); then compound 1.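

In this assay, swapping one methyl for hydrogen on a saturated chain carbon, two bonds along the chain from a carbonyl carbon, gives a number 17.8 percentage points lower from compound 2 to compound 4 (beyond the scatter). The three earlier compounds differed from one another in more than one place, so they could not single out this chain; this pair shows that, on this core, the maximal response can change beyond the usual scatter with the loss of a single carbon, turning propylcarbonyl into propanoyl. Nothing in hand accounts for the size of this step, which so far rests on one pair of compounds.

The compounds shown leave open whether the trend continues when the chain grows rather than shrinks, which a straight pentanoyl on the same core, with all else as in compound 2, would test. They also leave open whether the chain needs to be purely carbon, since an amine at its far end, or a hydroxyl in the same place, would ask how the response depends on what the chain carries.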